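A few compounds are considered here, and "the series" means these few. Any claim that something is new, unique, unknown or untested is made for them only; others in the source may bear on it.

Measured compounds in this set:

Compound 1, `Cc1cccc(CSc2cc(Cl)c(C)cc2S(=O)(=O)/N=C(\N)n2nccc2-c2ccccc2)c1`, gives 8000 nM.
Compound 2, `Cc1cccc(CSc2cc(Cl)c(C)cc2S(=O)(=O)/N=C(\N)n2nc(C)cc2-c2ccccc2)c1`, gives 155000 nM.
Compound 3, `Cc1cc(-c2ccccc2)n(/C(N)=N/S(=O)(=O)c2cc(C)c(Cl)cc2SCc2ccc(Cl)cc2)n1`, gives 3000 nM.

In a functional assay on HeLa cells (Homo sapiens) for cytotoxicity, read by MTT assay, with a stated time of 72 h (on this read-out higher numbers stand for weaker inhibition and lower numbers for stronger inhibition), compound 1 stands second highest of the three numbers; compound 3 sits lower and compound 2 sits higher. Compound 4, `Cc1cc(S(=O)(=O)/N=C(\N)n2nccc2-c2ccccc2)c(SCc2ccccc2C(F)(F)F)cc1Cl`, has not yet been measured. It differs from compound 1 in one place: 2-(trifluoromethyl)phenyl in place of 3-methylphenyl on a saturated chain carbon bound to a sulfur.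

Within the data shown here, one measured step touches this same place, the ring on the saturated chain carbon bound to a sulfur: a 52-fold lower number from compound 2 to compound 3 (1.71 log units; beyond the scatter). That is a large move, showing that this ring matters for the read-out. The other step, a 19-fold higher number from compound 1 to compound 2 (1.29 log units; beyond the scatter), concerns a different place and does not bear on the change here. Among the measured compounds shown here, the 2-(trifluoromethyl)phenyl group appears in no measured compound, so its effect cannot be read directly from the data.

Given the size of the one relevant step, a step beyond the scatter is expected, more likely toward a lower number, but with wide uncertainty. The expected step is a 1.6-fold lower number from compound 1 to compound 4 (0.20 log units; within the scatter). Compound 4 is therefore estimated at 5000 nM, within a range from 1000 nM to 25000 nM.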

Compound 4, half-maximal inhibitory concentration: 20000 nM
Compound 4: middle estimate off by 4.0-fold (0.60 log units), on the low side, and the stated range covers the measured number.
By their numbers in this assay, from the lowest: compound 3; then compound 1; then compound 4; then compound 2.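

In this assay, among these compounds, the step of a 2.5-fold higher number from compound 1 to compound 4 (0.40 log units; beyond the scatter) shows that changing the ring on the saturated chain carbon bound to a sulfur can also raise the number, while the only earlier step at this place, a 52-fold lower number from compound 2 to compound 3 (1.71 log units; beyond the scatter), lowered it. The direction of change at this place therefore depends on which group enters, at least across these two pairs, although the two steps start from different compounds: compound 2 carries a methyl in place of hydrogen on an aromatic carbon, and compound 1 does not. Nothing available gives a cause for the rise from the 3-methylphenyl to the 2-(trifluoromethyl)phenyl group.

On these data alone, it remains open whether 4-chlorophenyl would lower the number on the core of compound 1 as it does in compound 3. How a carboxylic acid or an amine on this ring would read is also unknown.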